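Swapping a silicon-bearing group for methoxymethoxy

The source may hold more compounds than are shown below. What is called first, only, known or untested is meant among the compounds shown, and "the series" means these compounds.

In a functional assay on MCF7 cells (Homo sapiens) for antiproliferative activity, read by MTT assay, with a stated time of 48 h (a higher number here means a weaker inhibitor, a lower number a stronger inhibitor), three compounds that share one core have been measured. Compound 1 (`COC/C1=C/C[C@](C)(CCC=C(C)C)/C=C/[C@@H](OC(=O)C=C(C)C)[C@](C)(O)/C=C/C1=O`) gives 4130 nM there, compound 2 (`CCN(CC)C/C1=C/C[C@](C)(CCC=C(C)C)/C=C/[C@@H](OC(=O)C=C(C)C)[C@](C)(O)/C=C/C1=O`) gives 130 nM and compound 3 (`CC[Si](CC)(CC)C/C1=C/C[C@](C)(CCC=C(C)C)/C=C/[C@@H](OC(=O)C=C(C)C)[C@](C)(O)/C=C/C1=O`) gives 3150 nM on the same read-out. Compound 3 thus sits level with compound 1 within the scatter and far from compound 2, the most potent of the three.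

Compound 4 (`COCOC/C1=C/C[C@](C)(CCC=C(C)C)/C=C/[C@@H](OC(=O)C=C(C)C)[C@](C)(O)/C=C/C1=O`) is still unmeasured. It carries methoxymethoxy in place of the silicon-bearing group of compound 3, on a saturated chain carbon bound to a double-bonded ring carbon (a group of 4 heavy atoms (2 carbon, 2 oxygen; no ring) in place of a group of 7 heavy atoms (6 carbon, 1 silicon; no ring), on a saturated chain carbon bound to a double-bonded ring carbon).

The closest measured precedent is a 1.3-fold lower number from compound 1 to compound 3 (0.12 log units; within the scatter), a step that links the same silicon-bearing group to methoxy, the group in the series that most resembles methoxymethoxy. The two large steps, a 32-fold lower number from compound 1 to compound 2 (1.50 log units; beyond the scatter) and a 24-fold higher number from compound 2 to compound 3 (1.38 log units; beyond the scatter), both involve the diethylamino group of compound 2, which compound 4 lacks.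

No step beyond the scatter is therefore expected in this assay for this change. The estimated step is a 1.1-fold higher number from compound 3 to compound 4 (0.05 log units; within the scatter) and stays within the scatter. Compound 4 is expected at 3500 nM with 1500 nM to 8000 nM as the estimated range.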

Compound 4, half-maximal inhibitory concentration: 3120 nM
Compound 4: the middle estimate sits 1.1-fold (0.05 log units) above what was measured; measured number inside the range.
By their numbers in this assay, from the lowest: compound 2; then compounds 4, 3 and 1 (each within the scatter of the next).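

In this assay, the result shows that this place on a saturated chain carbon bound to a double-bonded ring carbon tolerates the exchange of the silicon-bearing group for methoxymethoxy without a change beyond the scatter (a 1.0-fold lower number from compound 3 to compound 4 (0.00 log units; within the scatter)), even though the entering group carries hydrogen-bond acceptors and the leaving group has none. Compound 4 also stays level with the methoxy compound (a 1.3-fold lower number from compound 1 to compound 4 (0.12 log units; within the scatter)), whereas the step from the diethylamino compound remains large (a 24-fold higher number from compound 2 to compound 4 (1.38 log units; beyond the scatter)), so among the four compounds only compound 2 stands apart, as the most potent. Nothing available accounts for this pattern.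

The compounds shown leave open whether the large step belongs to diethylamino alone or extends to other amines, such as dimethylamino, pyrrolidine or morpholine. They also do not show whether a carboxylic acid or a longer ether chain at this place would stay level with compounds 1, 3 and 4 or move towards compound 2.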